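From fluoro to bromo on the benzyl group

A few compounds are considered here, and "the series" means these few. Any claim that something is new, unique, unknown or untested is made for them only; others in the source may bear on it.

compound 1 `COC(=O)c1ccc(NCc2cncn2Cc2cccc(N)c2)cc1-c1ccccc1`: > 10000 nM
compound 2 `COC(=O)c1ccc(NCc2cncn2Cc2ccc(F)cc2)cc1-c1ccccc1`: "not determined" (no result reported)
compound 3 `COC(=O)c1ccc(NCc2cncn2Cc2ccc(Br)cc2)cc1-c1ccccc1`: not yet measured

In a toxicity assay on NIH3T3 cells (Mus musculus) for cytotoxicity, read by resazurin assay (on this read-out higher numbers stand for an effect only at larger amounts of compound and lower numbers for an effect already at smaller amounts), compound 1 gives > 10000 nM, which is a limit of the assay and not a number. Compound 2 has no single number to stand on, its result being "not determined" (no result reported). The step bromo in place of fluoro on an aromatic carbon puts bromo in place of fluoro on an aromatic carbon, para to a large group. Among the compounds with values here, no measured step shows what this change does, so no shift beyond the scatter is expected in this assay. The estimated value for compound 3 is 12000 nM, expected within 4000 nM to 40000 nM.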

Compound 3, half-maximal effective concentration: > 10000 nM
Compound 3 was reported as a limit (the forecaster's own chance of this, stated with the estimate: 60%); the middle value lies beyond the limit too.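

Within the data shown here, compound 1 and compound 3 both stand at a limit of the assay and not at a number, so no step between them can be read. The compounds shown leave open what 4-bromobenzyl in place of 4-fluorobenzyl does in this assay.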